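Swapping the aryl group on a shared oxazole-bearing core

A few compounds are considered here, and "the series" means these few. Any claim that something is new, unique, unknown or untested is made for them only; others in the source may bear on it.

Measured compounds:
compound 1 `Cc1oc(-c2c(Cl)cccc2Cl)nc1CN1CCC(C(=O)NCCCN2C[C@H](C)C[C@H](C)C2)CC1`, 0.0483 h
compound 2 `CCCN(CCC)CCNC(=O)C1CCN(Cc2nc(-c3ccccc3C)oc2C)CC1`, > 0.5 h
compound 3 `COc1cccc(Br)c1-c1nc(CN2CCC(C(=O)NCCCN3C[C@H](C)C[C@H](C)C3)CC2)c(C)o1`, 0.0583 h

Three compounds have been run in an ADME assay on microsomes from liver (Rattus norvegicus) for metabolic stability, read by LC-MS, using NADPH, at 37 degrees C; on this read-out higher numbers stand for a longer-lived compound and lower numbers for a shorter-lived compound. Compound 1 gives 0.0483 h and compound 3 gives 0.0583 h; the two values are within the usual scatter of each other, so neither can be called the longer-lived. Compound 2 returns only a limit, > 0.5 h, as described in the limit of > 0.5 h in this assay, at which 1 of the 3 values shown sits. Compound 3 thus carries the highest of the two numbers that were actually read, with compound 1 the nearest to it.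

Among the measured compounds shown here, the single step measured between compounds that differ in one place is a 1.2-fold higher number from compound 1 to compound 3 (0.08 log units; within the scatter); it did not move the read-out beyond the scatter.

Compound 4 `Cc1cc(C)cc(-c2nc(CN3CCC(C(=O)NCCCN4C[C@H](C)C[C@H](C)C4)CC3)c(C)o2)c1` is not yet measured. It differs from compound 3 by 3,5-dimethylphenyl in place of 2-bromo-6-methoxyphenyl on an aromatic carbon. For the measured compounds named here, no measured step touches a 3,5-dimethylphenyl group, so the only guide is that the one aryl swap seen so far, from compound 1 to compound 3, stayed within the scatter. On that basis the step of a 1.0-fold higher number from compound 3 to compound 4 (0.01 log units; within the scatter) is expected to be small, with no direction beyond the scatter. Compound 4 is therefore estimated at 0.06 h in this assay, with a range from 0.025 h to 0.15 h.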

Compound 4, half-life: < 0.5 h
Compound 4 ended at the assay's limit (the forecaster's own chance of this, stated with the estimate: 10%); the middle value is on the limit's open side.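

In this assay compound 4 gives only a limit, < 0.5 h. Among the compounds shown here, no step to compound 4 can be read, neither from compound 3 nor from compound 1. The compounds shown leave open where the half-life of compound 4 lies, and whether 3,5-dimethylphenyl in place of 2-bromo-6-methoxyphenyl or 2,6-dichlorophenyl moves it beyond the scatter.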